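The compounds below may be only part of what the source reports. "The series", "measured", "known", "first", "only" and "open" are said of these compounds alone.

In a functional assay on MIA PaCa-2 cells (Homo sapiens) for inhibition, read by MTT assay, with a stated time of 4 days (a higher number here means a weaker inhibitor, a lower number a stronger inhibitor), compound 1 `COc1cc(NC(C)CCCNC(=O)NNC(=O)NCCCCCO)c2ncccc2c1` gives 168000 nM and compound 2 `CCOC(=O)N(C)C(c1ccccc1)c1ccccc1` gives 94000 nM. For the measured compounds named here, these two values lie within the usual scatter of each other, so the two compounds stand level on the numbers so far. Compound 3 `COc1cc(NC(C)CCCNC(=O)NNC(=O)N(CCO)CCO)c2ncccc2c1` keeps the core of compound 1 and carries bis(2-hydroxyethyl)amino in place of (5-hydroxypentyl)amino on a carbonyl carbon. Going by the values given here, no measured pair shows a change of this kind. In this assay no step beyond the scatter is expected, and the estimated step is a 1.1-fold lower number from compound 1 to compound 3 (0.05 log units; within the scatter). For compound 3 the estimated value is 150000 nM, with a range of 60000 nM to 300000 nM.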

Compound 3, half-maximal inhibitory concentration: > 250000 nM
Compound 3 was reported as a limit; the forecaster's own chance of this, stated with the estimate: 20%; at least 1.6-fold (0.22 log units) between middle value and limit.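

In this assay, compound 3 is reported only as a limit, > 250000 nM. Placing bis(2-hydroxyethyl)amino in place of (5-hydroxypentyl)amino on this carbonyl carbon gives an at least 1.4-fold higher number from compound 1 to compound 3 (0.17 log units; that floor lies within the scatter), so this change brings no gain in strength at this position. How large the step really is stays unknown, because the reading for compound 3 is a limit: the limit of > 250000 nM in this assay, at which 1 of the 3 values shown sits.

On these data alone, compound 1 and compound 3 both carry hydroxyl groups on this side chain, so the effect of removing them remains open. A plain dimethylamino group or a chain ending in a carboxylic acid could show whether this position tolerates anything stronger.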